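Phenyl for Cyclopentyl on an Aromatic Nitrogen

A few compounds are considered here, and "the series" means these few. Any claim that something is new, unique, unknown or untested is made for them only; others in the source may bear on it.

compound 1, `O=C(CCCCCCc1nc2ccccc2[nH]1)NO`: 2700 nM
compound 2, `O=C(CCCCCCc1nc2ccccc2n1C1CCCC1)NO`: 4800 nM

Both were tested in a functional assay on SK-OV-3 cells (Homo sapiens) for cytotoxicity; on this read-out lower numbers stand for stronger inhibition and higher numbers for weaker inhibition. Compound 2 holds the highest of the two numbers, with compound 1 as its nearest neighbour. For the measured compounds named here, the single measured step, a 1.8-fold higher number from compound 1 to compound 2 (0.25 log units; within the scatter), lies within the scatter. Compound 3 `O=C(CCCCCCc1nc2ccccc2n1-c1ccccc1)NO` differs from compound 2 by phenyl in place of cyclopentyl on an aromatic nitrogen. Going by the values given here, no measured step exchanges one carbon ring for another on that nitrogen, and the only step known, cyclopentyl replacing hydrogen, was small. For compound 3 the change expected is therefore a 1.1-fold lower number from compound 2 to compound 3 (0.03 log units; within the scatter), nothing beyond the scatter. Compound 3 is estimated at 4500 nM, between 1500 nM and 14000 nM.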

Compound 3, half-maximal inhibitory concentration: > 20000 nM
Compound 3: a limit, no number; the forecaster's own chance of this, stated with the estimate: 5%; at least 4.4-fold (0.64 log units) between middle value and limit.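

The aromatic nitrogen is not indifferent to the group it carries: cyclopentyl in place of hydrogen stayed within the scatter, but phenyl does not, giving an at least 4.1-fold higher number from compound 2 to compound 3 (0.61 log units; beyond the scatter) and an at least 7.4-fold higher number from compound 1 to compound 3 (0.86 log units; beyond the scatter). Exchanging a five-membered non-aromatic carbon ring for a six-membered aromatic one therefore matters at this position. Compound 3 gives > 20000 nM, which is a limit and not a number, so both steps have a floor but no known size.

As far as these compounds go, whether methyl or benzyl on this nitrogen would stay close to compound 2 remains open. So does whether an amine on the phenyl ring would bring the number back down.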